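A few compounds are considered here, and "the series" means these few. Any claim that something is new, unique, unknown or untested is made for them only; others in the source may bear on it.

Measured compounds in a functional assay on KG-1 cells (Homo sapiens) for antiproliferative activity; a higher number here means that more compound is needed for the effect, a lower number that less compound is needed:
compound 1 `NC(=O)c1cc(Cl)c2c(Cl)c(C#CCN3CCCC3=O)n([C@H]3CCCNC3)c2n1` gives 178 nM
compound 2 `CC(O)C#Cc1c(Cl)c2c(Cl)cc(C(N)=O)nc2n1[C@H]1CCCNC1` gives 147 nM
compound 3 `NC(=O)c1cc(Cl)c2c(Cl)c(C#CC3CCOCC3)n([C@H]3CCCNC3)c2n1` gives 69 nM

Compound 3 has the lowest number of the three; its nearest neighbour is compound 2, a 2.1-fold lower number from compound 2 to compound 3 (0.33 log units; beyond the scatter), and the furthest is compound 1, a 2.6-fold lower number from compound 1 to compound 3 (0.41 log units; beyond the scatter). Compound 4 `COCCC#Cc1c(Cl)c2c(Cl)cc(C(N)=O)nc2n1[C@H]1CCCNC1` differs from compound 3 by 2-methoxyethyl in place of oxan-4-yl on a triple-bonded carbon. Both steps that reach compound 3 replace an open-chain group on the triple-bonded carbon with the oxan-4-yl and both lower the number modestly; compound 4 moves back to an open-chain group, so a modest rise in this assay is expected, of the size a 1.9-fold higher number from compound 3 to compound 4 (0.28 log units; within the scatter). Compound 4 is therefore estimated at 130 nM, with a range from 60 nM to 280 nM.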

Compound 4, half-maximal effective concentration: 39 nM
Beside the measured number, compound 4's estimate is 3.3-fold (0.52 log units) above it; the measured number lies below the stated range.
By their numbers in this assay, from the lowest: compounds 4 and 3 (each within the scatter of the next); then compounds 2 and 1 (each within the scatter of the next).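

In this assay the oxan-4-yl ring is not required on the triple-bonded carbon: 2-methoxyethyl, with no ring, gives a 1.8-fold lower number from compound 3 to compound 4 (0.25 log units; within the scatter) and stays within the scatter, so an open chain does not by itself bring a higher number. Replacing 1-hydroxyethyl with 2-methoxyethyl gives a 3.8-fold lower number from compound 2 to compound 4 (0.58 log units; beyond the scatter) and remains beyond the scatter, as does methoxymethyl in place of 2-oxopyrrolidin-1-yl, with a 4.6-fold lower number from compound 1 to compound 4 (0.66 log units; beyond the scatter) on the saturated chain carbon. No supporting data explain these differences.

On these data alone, whether a longer ether chain or an amine on the triple-bonded carbon would keep the number in this range remains open.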